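The source may hold more compounds than are shown below. What is called first, only, known or untested is meant among the compounds shown, and "the series" means these compounds.

In an ADME assay on MRC5 cells (Homo sapiens) for cytotoxicity, read by MTT assay, with a stated time of 72 h (a higher number here means a weaker inhibitor, a lower number a stronger inhibitor), compound 2 (`CC1=CCC[C@H]2[C@](C)(CC3=CC(=O)C=CC3=O)[C@@H](C)CC[C@]12C`) gives > 200000 nM, which is a limit and not a number. Compound 1 (`CC(C)(C)C1=CC(=O)C=C(NCCC(=O)O)C1=O`) gives > 200000 nM, again a limit. Compound 3 (`CC(C)(C)C1=CC(=O)C=CC1=O`) gives > 200000 nM, also a limit. The whole picture so far is therefore (the limit of > 200000 nM in this assay, at which 3 of the 3 values shown sit), and compound 2 cannot be placed relative to the others.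

Compound 4 (`CC1=CCC[C@H]2[C@](C)(CC3=CC(=O)C=C(N[C@@H](C(=O)O)C(C)C)C3=O)[C@@H](C)CC[C@]12C`) differs from compound 2 by (1-carboxy-2-methylpropyl)amino in place of hydrogen on a double-bonded ring carbon, two ring bonds from the ring atom that bears a large group: (1-carboxy-2-methylpropyl)amino in place of hydrogen on a double-bonded ring carbon.

Among the compounds with values here, only one measured step bears on this change. It is a step that the two limits leave unreadable from compound 1 to compound 3, with hydrogen in place of (2-carboxyethyl)amino on a double-bonded ring carbon, an exchange of the reverse kind involving a different group. It offers no size to carry over, since neither compound 1, which has that group, nor compound 3, which lacks it, gave a number. Nothing measured points to a step beyond the scatter in this assay in either direction, so none is expected. The estimated step is a number no higher from compound 2 to compound 4 (the limit leaves the size open). For compound 4 the estimated value is 200000 nM, with an expected range of 100000 nM to 300000 nM, and a result reported only as a limit is the likeliest outcome.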

Compound 4, half-maximal inhibitory concentration: 85400 nM
Compound 4: middle estimate off by 2.3-fold (0.37 log units), on the high side, and the stated range ends above it.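

In this assay, putting (1-carboxy-2-methylpropyl)amino in place of hydrogen on a double-bonded ring carbon, two ring bonds from the ring atom that bears a large group, gives an at least 2.3-fold lower number from compound 2 to compound 4 (0.36 log units; beyond the scatter), so this position can respond to a substituent in a way that can be read. The earlier step between compound 1 and compound 3, the only one that touched such a carbon, cannot be read, since both ends are limits. Compound 4 is thus the only compound with a number rather than a limit, while the others remain at the same ceiling: the limit of > 200000 nM in this assay, at which 3 of the 4 values shown sit.

Going by these compounds, compound 2 gives > 200000 nM, which is a limit and not a number, so the true size of the step remains open. Also open, on these data alone, is whether the carboxylic acid, the amine nitrogen or the branched chain of the entering group carries the step, and whether a plain amine, a methyl ester or a longer chain on the same carbon would move the number on the core of compound 2.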